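Phenyl for isopropyl on the five-membered aromatic ring

The compounds below may be only part of what the source reports. "The series", "measured", "known", "first", "only" and "open" are said of these compounds alone.

Compound 3 `CC(C)c1cn2c(NC(=O)C3CCCC3)nc(-c3ccccc3)nc2n1` stands lowest of the two numbers in an assay on cell membranes for displacement of a labelled ligand from adenosine receptor A1 (Bos taurus); a lower number here means a stronger inhibitor, a higher number a weaker inhibitor: compound 3 gives 5.8 nM. Nearest is compound 1 `CC(=O)CNc1nc(-c2ccccc2)nc2nc(C)cn12`, which in this assay gives 12 nM, a gap that lies beyond the scatter. Compound 2 `CCC(=O)CNc1nc(-c2ccccc2)nc2nc(C)cn12` reaches only a limit in this assay, > 10000 nM. Among the compounds with values here, the single measured step, an at least 830-fold higher number from compound 1 to compound 2 (2.92 log units; beyond the scatter), sits on a saturated chain carbon bound to a carbonyl carbon, not on the five-membered aromatic ring; the limit of > 10000 nM in this assay, at which 1 of the 3 values shown sits, records that one of the values is a limit rather than a number.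

Compound 4 `O=C(Nc1nc(-c2ccccc2)nc2nc(-c3ccccc3)cn12)C1CCCC1` differs from compound 3 by phenyl in place of isopropyl on an aromatic carbon. Within the data shown here, no measured step touches this ring position, so the one measured step supplies no scale for it, and the expectation rests on the change alone. In this assay the step from compound 3 to compound 4 is expected to be a 2.6-fold higher number from compound 3 to compound 4 (0.41 log units; beyond the scatter), a modest shift with wide uncertainty. Compound 4 is expected to give 15 nM in this assay, within 3 nM to 80 nM.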

Compound 4, inhibition constant: 17 nM
The estimate for compound 4 lay 1.1-fold (0.05 log units) below the measured number; measured number inside the range.
By their numbers in this assay, from the lowest: compound 3; then compounds 1 and 4 (each within the scatter of the next). At a limit, above all of these: compound 2.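

Within the data shown here, the step to phenyl gives the first measured reading at this aromatic carbon of the five-membered aromatic ring: in this assay the change gives a 2.9-fold higher number from compound 3 to compound 4 (0.47 log units; beyond the scatter). Replacing isopropyl, with no ring, by phenyl, with its six-membered aromatic ring, therefore produces only a modest change, and compound 4 still gives 17 nM. Nothing at hand accounts for the size or direction of this step.

Among these compounds, compounds 1 and 2 differ from compound 3 in more than one place, so isopropyl and phenyl are the only two groups that can be compared directly at this carbon. Open, going by these compounds, is how a saturated ring such as cyclohexyl, or a ring carrying nitrogen such as pyridyl, would read here with the rest of compound 3 unchanged.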